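Mirror-Image Pyrrolidine at a Nicotinic Receptor

The source may report more compounds than this note shows. Statements on the series, on what has been measured and on what is new or still open speak of the compounds shown alone.

Compound 1: `c1cnc2[nH]c(C[C@@H]3CCCN3)cc2c1` gives 2750 nM in an assay on membranes from brain for displacement of a labelled ligand from Neuronal acetylcholine receptor; alpha4/beta2 (Rattus norvegicus); on this read-out higher numbers stand for weaker inhibition and lower numbers for stronger inhibition.
Compound 2: `CN1CCC[C@@H]1Cc1cc2cccnc2[nH]1` gives 2510 nM in this assay.

Both measured compounds share the same bicyclic core joined through a single carbon to a saturated five-membered ring that carries a nitrogen; compound 1 has a hydrogen on that nitrogen, compound 2 a methyl. Of the two numbers shown, compound 2 has the lower one, but its nearest neighbour is compound 1 and the gap between them sits within the scatter, so nothing can be said about which is the tighter binder.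

The step to compound 3, `CN1CCC[C@H]1Cc1cc2cccnc2[nH]1`, keeps every atom and bond: the two compounds have the same atoms and bonds and differ only in configuration as drawn: 1 of 1 stereo elements differ; a stereocentre at a saturated ring carbon is drawn R in compound 2 and S in compound 3. Among the measured compounds shown here, no measured pair in this set differs only in configuration, so there is no step to lean on. Mirror-image forms often differ in this assay, in either direction, and the size of such a step cannot be read from the numbers here. Compound 3 is therefore expected to lie near compound 2, with a broad range to allow for a real shift either way: an estimate of 3000 nM, between 500 nM and 15000 nM, which means an expected step of a 1.2-fold higher number from compound 2 to compound 3 (0.08 log units; within the scatter).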

Compound 3, inhibition constant: 691 nM
For compound 3 the middle estimate is 4.3-fold (0.64 log units) above the measured one; measured number inside the range.
By their numbers in this assay, from the lowest: compound 3; then compounds 2 and 1 (each within the scatter of the next).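

In this assay, the drawn configuration at the saturated ring carbon turns out to matter, which the first two compounds alone could not reveal: going from R to S gives a 3.6-fold lower number from compound 2 to compound 3 (0.56 log units; beyond the scatter), a modest step but one beyond the usual scatter of such measurements. The shift can be assigned to that single stereocentre because nothing else changes: the fact that compounds 2 and 3 differ only in the configuration as drawn The set also now holds a one-place comparison for the group on the ring nitrogen, since methyl in place of hydrogen on an amine nitrogen in a ring gives a 4.0-fold lower number from compound 1 to compound 3 (0.60 log units; beyond the scatter), so among compounds with the S configuration the methyl form has the stronger inhibition.

From the compounds shown here alone, what methyl in place of hydrogen does in the R series remains open, so these compounds cannot show whether the effect of the methyl depends on configuration. Going by these compounds, it is also open whether an ethyl group or a longer chain on that nitrogen would strengthen inhibition further or weaken it, and how a fluorine or a methoxy group on the shared core would change the number.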